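A few compounds are considered here, and "the series" means these few. Any claim that something is new, unique, unknown or untested is made for them only; others in the source may bear on it.

In a functional assay on KYSE-70 cells for antiproliferative activity against KYSE-70 cell line (Homo sapiens), read by MTT assay, with a stated time of 72 h (on this read-out higher numbers stand for weaker inhibition and lower numbers for stronger inhibition), compound 1 `O=C(Nc1cccc(F)c1)c1cc(=O)[nH]c2cc(Br)ccc12` gives 8900 nM. Compound 2 `CC(=O)c1ccc(-c2ccc3c(C(=O)Nc4cccc(F)c4)cc(=O)[nH]c3c2)cc1` stands at > 20000 nM, which is a limit of the assay and not a number. Compound 3 `O=C(Nc1cccc(F)c1)c1cc(=O)[nH]c2cc(-c3ccsc3)ccc12` has thiophen-3-yl in place of 4-acetylphenyl on an aromatic carbon. Among the measured compounds shown here, the only measured step at this place is an at least 2.2-fold higher number from compound 1 to compound 2 (0.35 log units; beyond the scatter), the step that brought in 4-acetylphenyl. With that group gone, a move to a lower number in this assay is expected, back towards the value of compound 1, and it is estimated as an at least 2.0-fold lower number from compound 2 to compound 3 (0.30 log units; that floor lies within the scatter). Compound 3 is expected at 10000 nM, within an estimated range of 3000 nM to 20000 nM.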

Compound 3, half-maximal inhibitory concentration: 5100 nM
The estimate for compound 3 lay 2.0-fold (0.29 log units) above the measured number; low and high end bracket the measured number.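

In this assay, an aromatic ring at this position does not by itself carry the loss seen with 4-acetylphenyl: thiophen-3-yl gives an at least 3.9-fold lower number from compound 2 to compound 3 (0.59 log units; beyond the scatter). Compound 2 stands at a limit of the assay and not a number, so this step gives only a floor: the limit of > 20000 nM in this assay, at which 1 of the 3 values shown sits. Thiophen-3-yl and bromo cannot be told apart, with a 1.7-fold lower number from compound 1 to compound 3 (0.24 log units; within the scatter).

Going by these compounds, it remains open whether the acetyl group or the six-membered ring goes with the weak result. An unsubstituted phenyl or a 4-aminophenyl at this place would help to separate the two.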